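Removing One Trifluoromethyl Group, Tested on a Second Core

The compounds below may be only part of what the source reports. "The series", "measured", "known", "first", "only" and "open" are said of these compounds alone.

Compound 1 `Cc1cc(=O)oc2cc(OCC(=O)c3cc(C(F)(F)F)cc(C(F)(F)F)c3)ccc12` carries two trifluoromethyl groups on its outer aromatic ring. In a functional assay on CWR22R cells (Homo sapiens) for antiproliferative activity, with a stated time of 96 h (on this read-out higher numbers stand for weaker inhibition and lower numbers for stronger inhibition), compound 1 gives 930 nM. Compound 2 `Cc1cc(=O)oc2cc(OCC(=O)c3cccc(C(F)(F)F)c3)ccc12` differs by hydrogen in place of trifluoromethyl on an aromatic carbon. In this assay compound 2 gives > 100000 nM, which is a limit of the assay rather than a number. That change brought an at least 100-fold higher number from compound 1 to compound 2 (2.03 log units; beyond the scatter). Compound 3 `O=C(COc1ccc2c(C(F)(F)F)cc(=O)oc2c1)c1cccc(C(F)(F)F)c1` rests on a different core; the difference between the two cores is not broken down here. In this assay compound 3 is reported as "not active" (no number reported), with no number given. Compound 4 `O=C(COc1ccc2c(C(F)(F)F)cc(=O)oc2c1)c1ccccc1` differs from compound 3 by hydrogen in place of trifluoromethyl on an aromatic carbon, the same kind of change as before, though here the place is not also meta to a trifluoromethyl group. Since compound 3 is already reported as "not active" (no number reported) and the earlier step was an at least 100-fold higher number from compound 1 to compound 2 (2.03 log units; beyond the scatter), compound 4 is expected to show weak or no inhibition as well. The estimate for compound 4 is 100000 nM, within 30000 nM to 300000 nM.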

Compound 4, half-maximal inhibitory concentration: "not active" (no number reported)
Nothing numeric was reported for compound 4; there is nothing to compare the estimate with.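

In this assay compound 3 gives "not active" (no number reported) and compound 4 gives "not active" (no number reported), so no step can be read between them. Left open is whether losing this trifluoromethyl group changes activity on this core at all.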